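The source may hold more compounds than are shown below. What is called first, only, known or untested is meant among the compounds shown, and "the series" means these compounds.

Measured so far in an ADME assay on MT4 cells (Homo sapiens) for cytotoxicity, read by MTT assay, with a stated time of 4 days; on this read-out lower numbers stand for higher toxicity in this test and higher numbers for lower toxicity in this test:
- compound 1 `Cc1cccc(Oc2nc(Nc3ccc(C#N)cc3)nc3ccccc23)c1`: 355000 nM
- compound 2 `COc1ccccc1Oc1nc(Nc2ccc(C#N)cc2)nc2ccccc12`: 150000 nM

The series keeps one shared core and varies the aryl group on the ether oxygen. Compound 2 stands at the lowest of the two numbers in this assay; the nearest is compound 1, and the step of a 2.4-fold lower number from compound 1 to compound 2 (0.37 log units; beyond the scatter) is modest but beyond the scatter.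

Compound 3 `Cc1cc(Br)c(Oc2nc(Nc3ccc(C#N)cc3)nc3ccccc23)c(Br)c1` is not yet measured. It differs from compound 2 in one place: 2,6-dibromo-4-methylphenyl in place of 2-methoxyphenyl on an oxygen on an aromatic ring. Going by the values given here, the only measured step that bears on this kind of change is a 2.4-fold lower number from compound 1 to compound 2 (0.37 log units; beyond the scatter), where a different aryl substitution pattern on the same oxygen moved the number by a modest amount beyond the scatter. With two measured compounds there is no basis for a direction, and two ring substituents change at once here, so a step of comparable or somewhat larger size in this assay is expected, in either direction.

For compound 3 the estimate is 100000 nM, range 30000 nM to 400000 nM, corresponding to an expected step of a 1.5-fold lower number from compound 2 to compound 3 (0.18 log units; within the scatter).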

Compound 3, half-maximal cytotoxic concentration: 25000 nM
Beside the measured number, compound 3's estimate is 4.0-fold (0.60 log units) above it; measured number outside the range, below it.
By their numbers in this assay, from the lowest: compound 3; then compound 2; then compound 1.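

In this assay, the aryl group on an oxygen on an aromatic ring can move the number much further than the earlier pair suggested: replacing 2-methoxyphenyl with 2,6-dibromo-4-methylphenyl gives a 6.0-fold lower number from compound 2 to compound 3 (0.78 log units; beyond the scatter), larger than the earlier 2.4-fold lower number from compound 1 to compound 2 (0.37 log units; beyond the scatter). Against the 3-methylphenyl group the same entering group gives a 14-fold lower number from compound 1 to compound 3 (1.15 log units; beyond the scatter), so 2,6-dibromo-4-methylphenyl sits at the low end of the three aryl groups on this read-out, where lower numbers stand for higher toxicity in this test. No measurement shown accounts for the drop, and the change brings in two bromines and a methyl group and removes a methoxy group at once, so the step cannot be assigned to any one of these.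

Open, on these data alone, is how much of the step belongs to the bromines and how much to the methyl group, which a phenyl ring carrying a single bromine would help to separate. Also open, as far as these compounds go, is whether a different group on the aryl ring, such as chlorine, an amine or a carboxylic acid, would move the number in the same direction.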